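This account rests on a few compounds, and the source may have more. Where it says the series, first, only, none or still open, it means among the compounds named here.

Measured so far:
compound 1, `CCCCCCCCCCn1cc(-c2nc3ccccc3cc2CCCC)nn1` — > 100 ug/mL
compound 2, `CCCCCCCCCCn1cc(-c2nc3ccccc3cc2CCCCC)nn1` — 88 ug/mL
compound 3, `CCCc1cc2ccccc2nc1-c1cn(-c2ccc(F)cc2)nn1` — > 100 ug/mL

In a functional assay on THP-1 cells (Homo sapiens) for cytotoxicity, read by MTT assay, with a stated time of 24 h (on this read-out lower numbers stand for stronger inhibition and higher numbers for weaker inhibition), compound 1 returns only a limit of the assay, > 100 ug/mL. Compound 2 gives a number in this assay, 88 ug/mL. The step of an at least 1.1-fold lower number from compound 1 to compound 2 (0.05 log units; that floor lies within the scatter) corresponds to the change (methyl in place of hydrogen on a saturated chain carbon, four bonds along the chain from an aromatic carbon); since compound 1 sits at a limit, only a floor for that step is known, and that floor lies within the scatter. Compound 3 likewise returns only a limit in this assay, > 100 ug/mL. Compound 3 therefore stands at the limit of > 100 ug/mL in this assay, at which 2 of the 3 values shown sit. The difference between the core of compound 1 and the core of compound 3 is not broken down here.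

Compound 4, `CCCCc1cc2ccccc2nc1-c1cn(-c2ccc(F)cc2)nn1`, is not yet measured in this assay. It differs from compound 3 by methyl in place of hydrogen on a saturated chain carbon, three bonds along the chain from an aromatic carbon. The place is not the same as in the earlier pair: there the methyl entered four bonds along the chain from an aromatic carbon, here three bonds along the chain from an aromatic carbon, so this is the same kind of change, not the same change. The step of a number no higher from compound 3 to compound 4 (the limit leaves the size open) is expected to be small. This rests on compound 1 to compound 2, whose step an at least 1.1-fold lower number from compound 1 to compound 2 (0.05 log units; that floor lies within the scatter) does not leave the scatter, and on compound 3, whose value > 100 ug/mL is itself a limit. Compound 4 is estimated at 100 ug/mL, between 50 ug/mL and 250 ug/mL, and most likely the assay again reports only a limit.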

Compound 4, half-maximal inhibitory concentration: 78.3 ug/mL
Compound 4: middle estimate off by 1.3-fold (0.11 log units), on the high side; low and high end bracket the measured number.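

In this assay, methyl in place of hydrogen on a saturated chain carbon, read on the chain as propyl to butyl, gives an at least 1.2-fold lower number from compound 3 to compound 4 (0.10 log units; that floor lies within the scatter). Neither this step nor the earlier one leaves the scatter, and the change sits at different places, four bonds along the chain from an aromatic carbon on the core of compound 1 and three bonds along the chain from an aromatic carbon on the core of compound 3, so the data do not establish a real effect of the change or a size that carries from one core to the other: the same change on two cores in this assay, an at least 1.1-fold lower number (0.05 log units; that floor lies within the scatter) from compound 1 to compound 2 and an at least 1.2-fold lower number (0.10 log units; that floor lies within the scatter) from compound 3 to compound 4; the limit leaves it open whether they differ Nothing here contradicts carrying the change across the two cores, but the limits keep the comparison open-ended: the limit of > 100 ug/mL in this assay, at which 2 of the 4 values shown sit.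

The compounds shown leave open whether a longer chain, such as hexyl or octyl, in place of the butyl of compound 4 would give a step beyond the scatter in this assay. They also leave open how an amine or a carboxylic acid at the end of that chain would read, and whether the same change would behave alike at other places on the chain.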